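The source may hold more compounds than are shown below. What is called first, only, known or untested is meant among the compounds shown, and "the series" means these compounds.

Measured so far in an assay on isolated protein for inhibition of lysosomal alpha-glucosidase (Rattus norvegicus), read by colorimetric assay; on this read-out higher numbers stand for weaker inhibition and lower numbers for stronger inhibition:
- compound 1, `Cc1ccc(S(=O)(=O)Nc2ccc3c(c2)C(=O)N(Cc2ccccc2)C3=O)cc1`: > 200000 nM, which is a limit of this assay and not a number
- compound 2, `Cc1ccc(S(=O)(=O)Nc2ccc3c(c2)C(=O)N(Cc2ccccc2F)C3=O)cc1`: 195000 nM

Going by the values given here, compound 2 carries the only number in this assay; the other value is a limit. Among the compounds with values here, the single measured step, an at least 1.0-fold lower number from compound 1 to compound 2 (0.01 log units; that floor lies within the scatter), is a fluoro in place of hydrogen on an aromatic carbon, and its size rests on (the limit of > 200000 nM in this assay, at which 1 of the 2 values shown sits), so no direction can be read from it.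

Compound 3, `Cc1ccc(S(=O)(=O)Nc2ccc3c(c2)C(=O)N(CCOc2ccc(O)cc2)C3=O)cc1`, differs from compound 2 by (4-hydroxyphenoxy)methyl in place of 2-fluorophenyl on a saturated chain carbon bound to an amide-type nitrogen in a ring. Within the data shown here, no measured step changes this part of the core, and the one step that is measured does not reach beyond the scatter, so there is no basis for expecting a shift in either direction in this assay beyond the scatter. The value of compound 3 is therefore expected close to that of compound 2, with the step of a 1.0-fold higher number from compound 2 to compound 3 (0.01 log units; within the scatter) estimated as small, and compound 3 is estimated at 200000 nM, within 60000 nM to 600000 nM.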

Compound 3, half-maximal inhibitory concentration: 47700 nM
Compound 3: middle estimate off by 4.2-fold (0.62 log units), on the high side, outside the stated range (below it).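

In this assay, the saturated chain carbon bound to an amide-type nitrogen in a ring is now a place where a change moves the number beyond the scatter: (4-hydroxyphenoxy)methyl in place of 2-fluorophenyl gives a 4.1-fold lower number from compound 2 to compound 3 (0.61 log units; beyond the scatter). With (4-hydroxyphenoxy)methyl in place of phenyl, the series shows an at least 4.1-fold lower number from compound 1 to compound 3 (0.62 log units; beyond the scatter), which sets a floor and not a size. Compound 1 stands at > 200000 nM, which is a limit of the assay and not a number, so this second step can be read only as a floor: the limit of > 200000 nM in this assay, at which 1 of the 3 values shown sits.

The entering group differs from 2-fluorophenyl in several features at once, including the hydroxyl and the ether oxygen, and the compounds shown do not separate their contributions. Going by these compounds, it remains open whether an unsubstituted phenoxymethyl, a methoxy group in place of the hydroxyl, or an amine or carboxylic acid at this place on the ring would keep, extend or lose the shift in this assay.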